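A few compounds are considered here, and "the series" means these few. Any claim that something is new, unique, unknown or untested is made for them only; others in the source may bear on it.

Measured compounds:
- compound 1 `Cc1ccc(NC(=O)c2ccc(/N=N\c3c[nH]c4ccccc34)cc2)cc1`: 300 nM
- compound 2 `Cc1cccc(NC(=O)c2ccc(/N=N\c3c[nH]c4ccccc34)cc2)c1C`: 51600 nM
- compound 3 `O=C(Nc1ccccc1Cl)c1ccc(/N=N\c2c[nH]c3ccccc23)cc1`: "not active" (no number reported)

The three compounds above share one core and differ only in the aryl group on the amide nitrogen. In a functional assay on P388 cells (Mus musculus) for inhibition, read by MTT assay, with a stated time of 72 h (on this read-out higher numbers stand for weaker inhibition and lower numbers for stronger inhibition), compound 1 gives 300 nM and compound 2 gives 51600 nM; the step of a 170-fold higher number from compound 1 to compound 2 (2.24 log units; beyond the scatter) shows that the move to 2,3-dimethylphenyl costs a great deal. Compound 3 has no single number in this assay, since it is recorded as "not active" (no number reported).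

Compound 4 `Cc1cccc(NC(=O)c2ccc(/N=N\c3c[nH]c4ccccc34)cc2)c1` is the next compound. The change from compound 3 to compound 4 is 3-methylphenyl in place of 2-chlorophenyl on an amide-type nitrogen. Within the data shown here, no measured step covers this exact change, so the expectation rests on the spread seen among compounds 1, 2 and 3. Compound 4 is expected to give about 5000 nM, within a range from 400 nM to 80000 nM.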

Compound 4, half-maximal inhibitory concentration: 300 nM
Beside the measured number, compound 4's estimate is 17-fold (1.22 log units) above it; the whole stated range lies above it.
By their numbers in this assay, from the lowest: compounds 1 and 4 (each within the scatter of the next); then compound 2.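

Taking one methyl off the 2,3-dimethylphenyl group gives a 170-fold lower number from compound 2 to compound 4 (2.24 log units; beyond the scatter) in this assay and brings the number back to that of compound 1. Changing 4-methylphenyl to 3-methylphenyl gives no change at the digits printed from compound 1 to compound 4 (within the scatter) here, so among these compounds a single methyl is tolerated in either form, and only the two methyls of compound 2 come with the large loss. Compound 3 has no number, so its steps cannot be read, and nothing measured here explains these differences. On these data alone, how an amine, a carboxylic acid or a longer chain such as propyl on this aryl group would fare remains open.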